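Lengthening a chain at an amide-type nitrogen

This account rests on a few compounds, and the source may have more. Where it says the series, first, only, none or still open, it means among the compounds named here.

Compound 1, `CNC(=S)N1N=C(c2ccc(C)cc2)CC1c1ccc[nH]1`, gives 12.2% in a functional assay on the whole organism (strain Swiss Albino) for inhibition, with Mus musculus as the target, read by paw edema, with a stated time of 270 min, at a dose of 100 mg/kg by the oral route; on this read-out higher numbers stand for more inhibition at the one dose given (going by the name of the read-out) and lower numbers for less inhibition.
Compound 2, `CCNC(=S)N1N=C(c2ccc(C)cc2)CC1c1ccc[nH]1`, gives 12.4% in this assay.
Compound 3, `CCNC(=S)N1N=C(c2ccc(OC)cc2)CC1c1ccc[nH]1`, gives 18.9% in this assay.

Compound 1 and compound 2 share a core and differ in one place: methyl in place of hydrogen on a saturated chain carbon bound to an amide-type nitrogen. This change made a step of a number 0.2 percentage points higher from compound 1 to compound 2 (within the scatter). Compound 2 and compound 3 also differ in one place, and that step reads a number 6.5 percentage points higher from compound 2 to compound 3 (within the scatter). The difference between the core of compound 1 and the core of compound 3 is not broken down here; their two values simply stand as given.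

Compound 4, `CCCNC(=S)N1N=C(c2ccc(OC)cc2)CC1c1ccc[nH]1`, has not yet been measured in this assay. It differs from compound 3 in one place: methyl in place of hydrogen on a saturated chain carbon, two bonds along the chain from an amide-type nitrogen. For the measured compounds named here, this is the same kind of change as the one from compound 1 to compound 2, but not the same: there the entering methyl sat on a saturated chain carbon bound to an amide-type nitrogen, whereas here it sits on a saturated chain carbon two bonds along the chain from an amide-type nitrogen. Since the earlier step of this kind, a number 0.2 percentage points higher from compound 1 to compound 2 (within the scatter), lay within the scatter, the step from compound 3 to compound 4 is expected to be small as well, about a number 1.1 percentage points higher from compound 3 to compound 4 (within the scatter). On that basis compound 4 is estimated to give 20% in this assay, with a likely range from 10% to 30%.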

Compound 4, a percentage reported as inhibition, in the whole organism at one dose (the size of the read-out at that dose, not a potency): 22.6%
Estimate against measurement, compound 4: 2.6 percentage points below, within the range that was stated.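

In this assay, adding one more methyl to the chain gave a number 3.7 percentage points higher from compound 3 to compound 4 (within the scatter). Set beside the earlier step of this kind, the result on the two cores can be summed up in one comparison: the same change on two cores in this assay, a number 0.2 percentage points higher (within the scatter) from compound 1 to compound 2 and a number 3.7 percentage points higher (within the scatter) from compound 3 to compound 4, 3.5 percentage points apart, within the scatter of two such steps. This shows that, on both cores, the change stayed within the ordinary spread of repeated measurements and that the two steps cannot be told apart, so nothing here marks the core as altering the outcome; it does not show that the change has no effect, or that its effect is identical on both cores, since small real effects could lie hidden in that spread, and two pairs, with the methyl entering at different places along the chain, are a thin basis for a general rule.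

The compounds shown leave open what a longer chain such as butyl, a branched chain such as isopropyl, or a chain ending in an amine or a carboxylic acid would give in place of propyl, and whether any of these would produce a step beyond the scatter. Going by these compounds, each number also describes a single dose and time, so how these compounds would compare under other conditions remains open.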